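A Second Chloro on the Benzyl Ring

The source may report more compounds than this note shows. Statements on the series, on what has been measured and on what is new or still open speak of the compounds shown alone.

In a functional assay on HeLa cells (Homo sapiens) for antiproliferative activity, read by MTT assay, with a stated time of 48 h, in the presence of a further agent that is not named here (on this read-out higher numbers stand for weaker inhibition of growth and lower numbers for stronger inhibition of growth), compound 1 `O=C(NOCc1ccccc1F)c1cn(-c2ccccc2)nc1-c1ccc(Cl)cc1` gives 4170 nM, and compound 2 `O=C(NOCc1ccccc1Cl)c1cn(-c2ccccc2)nc1-c1ccc(Cl)cc1` gives 8850 nM. Compound 2 stands highest of the two numbers shown, and the only other value, that of compound 1, is separated from it by the step of a 2.1-fold higher number from compound 1 to compound 2 (0.33 log units; beyond the scatter). Compound 3 `O=C(NOCc1ccc(Cl)cc1Cl)c1cn(-c2ccccc2)nc1-c1ccc(Cl)cc1` differs from compound 2 by chloro in place of hydrogen on an aromatic carbon. Going by the values given here, the one measured step, a 2.1-fold higher number from compound 1 to compound 2 (0.33 log units; beyond the scatter), exchanges one halogen for another on the same ring rather than putting chloro in place of hydrogen, so it bears on this change only indirectly: it shows that a small change on this benzyl ring moved this assay modestly. Among the compounds with values here, no measured step adds a second chloro, so the direction is open. The step from compound 2 to compound 3 is therefore expected to be a 1.0-fold higher number from compound 2 to compound 3 (0.01 log units; within the scatter), close to the scatter. Compound 3 is expected to give 9000 nM, with a range from 3500 nM to 23000 nM.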

Compound 3, concentration for 50% growth inhibition: 5160 nM
Estimate against measurement, compound 3: 1.7-fold (0.24 log units) above; the range from low to high includes it.
By their numbers in this assay, from the lowest: compounds 1, 3 and 2 (each within the scatter of the next, the first and the last beyond it).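

In this assay the new chloro, para to a large group and meta to a chloro group, gives a 1.7-fold lower number from compound 2 to compound 3 (0.23 log units; within the scatter) and so cannot be told apart from hydrogen at this place on the 2-chlorobenzyl group. The 2,4-dichlorobenzyl compound also gives a 1.2-fold higher number from compound 1 to compound 3 (0.09 log units; within the scatter) against the 2-fluorobenzyl compound, so compound 3 sits within the scatter of both earlier compounds even though those two lie beyond the scatter of each other; this position therefore tolerates a chloro without a clear shift on this read-out, at least in these three compounds. Nothing given here offers an explanation for this result.

Going by these compounds, whether a methoxy group or an amine at this same place would leave the read-out equally unmoved remains open. So does whether a fluoro there would behave as the chloro does, or whether a longer chain between the oxygen and the ring would matter more.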